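The source may hold more compounds than are shown below. What is called first, only, known or untested is meant among the compounds shown, and "the series" means these compounds.

Three compounds carry a shared core and differ only on the aromatic ring or the chain. Compound 1 `CN(C)C(=O)c1cc2cnc(Nc3ccc(C(=O)NCCCN=C=S)cc3)nc2n1C1CCCC1` gives 103% in a functional assay on A549 cells (Homo sapiens) for inhibition, read by CCK-8 assay, with a stated time of 72 h, tested at 10 uM; a higher number here means a stronger effect of the compound at the concentration tested, a lower number a weaker effect. Compound 2 `CN(C)C(=O)c1cc2cnc(Nc3ccc(C(=O)NCCCN=C=S)cc3F)nc2n1C1CCCC1` gives 60.2% in this assay, the second highest of the three numbers, and compound 3 `CN(C)C(=O)c1cc2cnc(Nc3ccc(C(=O)NCCCCCCN=C=S)cc3F)nc2n1C1CCCC1` gives 22.9%. The step of a number 42.8 percentage points lower from compound 1 to compound 2 (beyond the scatter) was large, as was the step of a number 37.3 percentage points lower from compound 2 to compound 3 (beyond the scatter).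

Compound 4 `CN(C)C(=O)c1cc2cnc(Nc3ccc(C(=O)NCCCN=C=S)cc3O)nc2n1C1CCCC1` is not yet measured. It differs from compound 2 by hydroxy in place of fluoro on an aromatic carbon. Of the measured steps only a number 42.8 percentage points lower from compound 1 to compound 2 (beyond the scatter) touches the same aromatic carbon, and there the entry of fluoro cost much. Hydroxy is a different group from hydrogen, so that step gives only a loose guide; the step of a number 37.3 percentage points lower from compound 2 to compound 3 (beyond the scatter) concerns the chain and does not bear on this change. He therefore expects the number for compound 4 to move back upward, the step of a number 14.8 percentage points higher from compound 2 to compound 4 (beyond the scatter) being his estimate, though with wide uncertainty. He estimates compound 4 at 75%, within a range from 35% to 105%.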

Compound 4, a percentage reported as inhibition, at one concentration (the size of the read-out at that concentration, not a potency): 73%
Estimate against measurement, compound 4: 2 percentage points above, within the range that was stated.
By their numbers in this assay, from the lowest: compound 3; then compound 2; then compound 4; then compound 1.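

At this aromatic carbon, ortho to a large group, the outcome depends on which group enters: in this assay, hydroxy in place of fluoro gives a step of a number 12.8 percentage points higher from compound 2 to compound 4 (beyond the scatter) and so shows that the earlier loss was not the same for every group placed here. Hydroxy still does not match hydrogen, with a step of a number 30 percentage points lower from compound 1 to compound 4 (beyond the scatter) in the same assay, so both groups shown at this carbon stand below the unsubstituted ring of compound 1. Nothing available explains the difference between fluoro and hydroxy at this carbon.

On these data alone, it remains open whether an amine or a methoxy group at this carbon would come closer to hydrogen or stay nearer to fluoro. As far as these compounds go, it is also open whether hydroxy would give a similar step when paired with the longer chain of compound 3.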